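The compounds below may be only part of what the source reports. "The series", "measured", "known", "first", "only" and "open" are said of these compounds alone.

Measured so far in an ADME assay on CEM-SS cells (Homo sapiens) for cytotoxicity, read by XTT assay, with a stated time of 6 days; a lower number here means that less compound is tolerated, a higher number that more compound is tolerated:
- compound 1 `CCCC(=O)OCSc1ccccc1C(=O)NCCC(N)=O` gives > 100 uM which is a limit and not a number
- compound 2 `CCCC(=O)OCSc1ccccc1C(=O)N[C@H]1CCC[C@@H]1C(N)=O` gives 31.2 uM; 43.3 uM (2 entries) from repeated measurements
- compound 3 `CCCC(=O)OCSc1ccccc1C(=O)NCC(=O)OC` gives 27.3 uM as a single measurement

Among the compounds with values here, compound 3 holds the only single number here, and the entries of compound 2 the several entries of compound 2 in this assay, 31.2 uM; 43.3 uM (2 entries) lie within the scatter of it. Compound 1 stands at a limit of > 100 uM in this assay, at which 1 of the 3 values shown sits, instead of a number.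

The next compound, compound 4 `CCCC(=O)OCSc1ccccc1C(N)=O`, is reached by one change: hydrogen in place of (methoxycarbonyl)methyl on an amide-type nitrogen. Within the data shown here, one measured step bears on this: an at least 3.6-fold lower number from compound 1 to compound 3 (0.56 log units; beyond the scatter), and it brought in the methoxycarbonyl group that compound 4 no longer carries. A move to a higher number is therefore expected in this assay. Compound 2 goes against this pattern, since it has no methoxycarbonyl group and still gives 31.2 uM; 43.3 uM (2 entries), so only a modest rise is expected. Compound 4 is estimated at 50 uM, with an expected range from 22 uM to 110 uM in this measurement. That estimate means an expected 1.8-fold higher number from compound 3 to compound 4 (0.26 log units; within the scatter) overall.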

Compound 4, half-maximal toxic concentration: 12.4 uM
For compound 4 the middle estimate is 4.0-fold (0.61 log units) above the measured one; the measured number lies below the stated range.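

In this assay, taking the whole (methoxycarbonyl)methyl group off the amide-type nitrogen does not raise the number; the change gives a 2.2-fold lower number from compound 3 to compound 4 (0.34 log units; beyond the scatter), so the methoxycarbonyl group alone does not account for the low tolerance of compound 3. Compound 1 gives > 100 uM, which is a limit and not a number. Measured against that limit the step is an at least 8.0-fold lower number from compound 1 to compound 4 (0.90 log units; beyond the scatter), so both substituents shown on this nitrogen, the 2-carbamoylethyl chain and the (methoxycarbonyl)methyl group, go with more compound tolerated than hydrogen does.

Going by these compounds, it stays open whether the high tolerance of compound 1 depends on its end carbamoyl group or on the length of its chain. A plain methyl group on this nitrogen, or a chain of the same length ending in a carboxylic acid or an amine, would help separate these two readings.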